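The compounds below may be only part of what the source reports. "The series", "measured", "known", "first", "only" and "open" are said of these compounds alone.

Working notes on the series

Three members of the series have been run in an assay on HEK293 cells for activation of Kir3.1/Kir3.2 (Homo sapiens), read by thallium flux; on this read-out higher numbers stand for larger maximal responses and lower numbers for smaller maximal responses. Compound 1 `Cc1cc(NC(=S)Cn2nnc(-c3ccccc3)n2)n(C2CCCCC2)n1`, the thioamide with a plain cyclohexyl on the ring nitrogen, gives 80% in this assay. Compound 3 `O=C(Cn1nnc(-c2ccccc2)n1)Nc1cc(C2(C(F)(F)F)CC2)nn1C1CCCCC1`, which carries a trifluoromethylcyclopropyl in place of the methyl, is reported as "not active" (no number reported) in this assay, without a number. Compound 2 `Cc1cc(NC(=O)Cn2nnc(-c3ccccc3)n2)n(C2CCC(C)(C)CC2)n1`, the amide bearing 4,4-dimethylcyclohexyl, is reported in this assay only as a limit, > 19%, so no single number fixes its place. Of the three values shown, one sits at a limit (the limit of > 19% in this assay, at which 1 of the 3 values shown sits), and compound 2 is that one; the other two are a number and an entry without a number. For the measured compounds named here, no pair of measured compounds differs in one place, so no measured step is available as a guide.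

Compound 4 `Cc1cc(NC(=O)Cn2nnc(-c3ccccc3)n2)n(-c2ccccc2)n1` is not yet measured in this assay. It differs from compound 2 as follows: phenyl in place of 4,4-dimethylcyclohexyl on an aromatic nitrogen. The change sits on an aromatic nitrogen of a five-membered aromatic ring with 2 nitrogen, where the cyclohexyl of compound 1 and the 4,4-dimethylcyclohexyl of compound 2 sit.

With compound 2 known only as a limit, the size of the step to compound 4 is uncertain; the expected step from compound 2 to compound 4 is a step that the limit leaves unreadable from compound 2 to compound 4, an expected rise beyond the scatter. Compound 4 is estimated at 50% in this assay, in the range 20% to 85%.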

Compound 4, largest response reached (Emax), in percent of the reference or control that the assay uses: 66%
Beside the measured number, compound 4's estimate is 16 percentage points below it; measured number inside the range.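

The step from compound 2 to compound 4 cannot be read in this assay, because compound 2 is known only as a limit: the limit of > 19% in this assay, at which 1 of the 4 values shown sits.

The compounds shown leave open how large the change from 4,4-dimethylcyclohexyl to phenyl on the aromatic nitrogen is, and whether compound 4 differs from compound 2 beyond the usual scatter.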